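This account rests on a few compounds, and the source may have more. Where it says the series, first, only, none or still open, it means among the compounds named here.

Compound 1 `N#Cc1ccc(Nc2nccc(OCc3ccc(Cl)cc3)n2)cc1`: 156000 nM
Compound 2 `N#Cc1ccc(Nc2nccc(OCc3cccc(Br)c3)n2)cc1`: 221000 nM

Both compounds were tested in an ADME assay on MT4 cells (Homo sapiens) for cytotoxicity, read by MTT assay, with a stated time of 5 days (on this read-out higher numbers stand for lower toxicity in this test and lower numbers for higher toxicity in this test), a read-out of how much compound is needed to harm cultured cells. Compound 2 and compound 1 sit close together: the step of a 1.4-fold higher number from compound 1 to compound 2 (0.15 log units; within the scatter) lies within the scatter, so neither can be called less toxic than the other on these two numbers alone.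

Compound 3 `N#Cc1ccc(COc2ccnc(Nc3ccc(C#N)cc3)n2)cc1` has not yet been measured. It differs from compound 2 in one place: 4-cyanophenyl in place of 3-bromophenyl on a saturated chain carbon bound to an oxygen on an aromatic ring.

Going by the values given here, only one measured step bears on this, and only loosely. That step, a 1.4-fold higher number from compound 1 to compound 2 (0.15 log units; within the scatter), exchanged 4-chlorophenyl for 3-bromophenyl on the same saturated chain carbon and changed nothing beyond the scatter. Among the compounds with values here, no measured pair exchanges a bromine-bearing ring for a nitrile-bearing one, so there is no direct precedent for compound 3. Within the data shown here, with the one available step flat, the expectation is a step of a 1.2-fold lower number from compound 2 to compound 3 (0.09 log units; within the scatter), that is, nothing beyond the scatter in either direction.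

Compound 3 is therefore estimated at 180000 nM, with a range from 80000 nM to 400000 nM.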

Compound 3, half-maximal cytotoxic concentration: 209000 nM
For compound 3 the middle estimate is 1.2-fold (0.06 log units) below the measured one; measured number inside the range.
By their numbers in this assay, from the lowest: compounds 1, 3 and 2 (each within the scatter of the next).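

In this assay, a nitrile-bearing ring can now be set against the halogen-bearing rings on a saturated chain carbon bound to an oxygen on an aromatic ring: 4-cyanophenyl in place of 3-bromophenyl gives a 1.1-fold lower number from compound 2 to compound 3 (0.02 log units; within the scatter). Putting cyano in place of chloro on an aromatic carbon gives a 1.3-fold higher number from compound 1 to compound 3 (0.13 log units; within the scatter), so this more direct exchange of one ring substituent for another also stays within the scatter, and the hydrogen-bond acceptor counted for 4-cyanophenyl comes with no change that can be read. The three rings tried at this place therefore cannot be told apart on this read-out, and no supporting measurement is available to explain that result.

On these data alone, all three compounds carry a halogen or a nitrile on a carbon-only aromatic ring, so it remains open whether an amine, a carboxylic acid or a longer chain at this place would move the number beyond the scatter. The shared core is also unchanged throughout, which leaves open how changes there would register in this assay.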